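The source may report more compounds than this note shows. Statements on the series, on what has been measured and on what is new or still open speak of the compounds shown alone.

Measured so far in a functional assay on CHO cells for agonist activity at Free fatty acid receptor 1 (Homo sapiens), read by a luciferase reporter; a lower number here means a smaller maximal response, a higher number a larger maximal response:
compound 1 `O=C(O)COc1ccc(NCc2cccc(Oc3ccccc3)c2)cc1` gives 84%
compound 2 `CC(CC(=O)O)c1ccc(NCc2cccc(Oc3ccccc3)c2)cc1` gives 83%
compound 3 `Cc1nc(-c2ccc(C(F)(F)F)cc2)sc1CNc1ccc([C@H]2C[C@@H]2C(=O)N(C)C)cc1` gives 49%

Compound 2 stands second of the three numbers: compound 1 lies within the scatter of it, while compound 3 lies well below it, beyond the scatter. Among the compounds with values here, the only single-point step recorded, a number 1 percentage points lower from compound 1 to compound 2 (within the scatter), exchanges one acid-bearing side chain for another on an aromatic carbon and moves the maximal response by nothing beyond the scatter.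

Compound 4 `O=C(NO)[C@H]1C[C@@H]1c1ccc(NCc2cccc(Oc3ccccc3)c2)cc1` differs from compound 2 by 2-(hydroxycarbamoyl)cyclopropyl in place of 1-(carboxymethyl)ethyl on an aromatic carbon. Within the data shown here, compound 3 also carries a substituted cyclopropyl on an aromatic carbon, but it differs from compound 2 in several places at once, so no step can be read from it; its value shows only that a cyclopropyl-bearing member of the series can reach a markedly lower maximal response. Among the measured compounds shown here, the one step that directly bears on the change was flat, yet the acid itself is replaced here rather than merely relocated, and compound 3 counsels some caution.

Compound 4 is therefore expected to give 74%, in a range of 52% to 92%. The expected step is a number 9 percentage points lower from compound 2 to compound 4 (within the scatter), with the lower part of the range allowing for a drop toward compound 3.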

Compound 4, largest response reached (reported as percent of maximum), in percent of the reference or control that the assay uses: 90%
Beside the measured number, compound 4's estimate is 16 percentage points below it; the measured number falls inside the stated range.
By their numbers in this assay, from the lowest: compound 3; then compounds 2, 1 and 4 (each within the scatter of the next).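

In this assay, 2-(hydroxycarbamoyl)cyclopropyl in place of 1-(carboxymethyl)ethyl gives a number 7 percentage points higher from compound 2 to compound 4 (within the scatter), and the same group in place of carboxymethoxy gives a number 6 percentage points higher from compound 1 to compound 4 (within the scatter). On this core, the aromatic carbon para to a large group therefore need not carry a carboxylic acid side chain, since a hydroxycarbamoyl group on a three-membered carbon ring keeps the maximal response within the scatter of both acid-bearing compounds. No available measurement explains this flat result.

The change alters the ring and the acid-bearing end together, so their separate contributions remain unresolved. A cyclopropyl bearing a carboxylic acid and an open chain ending in hydroxycarbamoyl would separate them, while the opposite cyclopropyl stereoisomer would test the role of the defined stereocentres.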